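The compounds below may be only part of what the source reports. "The series", "measured", "known", "first", "only" and "open" are said of these compounds alone.

Compound 1 `COc1cc(-c2nn(-c3cccc(NC(=O)c4ccc(Cl)c(C(F)(F)F)c4)c3)cc2-c2ccncc2)ccc1Cl` was tested in a functional assay on NCI-H226 cells (Homo sapiens) for inhibition, read by sulforhodamine B assay, with a stated time of 48 h; on this read-out higher numbers stand for weaker inhibition of growth and lower numbers for stronger inhibition of growth. In this assay compound 1 gave only a limit, > 32500 nM. Compound 2 `O=C(Nc1cccc(-n2cc(-c3ccncc3)c(-c3ccc(Cl)c(O)c3)n2)c1)Nc1ccc(Cl)c(C(F)(F)F)c1` likewise gave only a limit in this assay, > 32500 nM. For the measured compounds named here, both values sit at the limit of > 32500 nM in this assay, at which 2 of the 2 values shown sit, so compound 1 stands at the same limit as the one other measured compound and cannot be placed above or below it. Compound 3 `COc1cc(-c2nn(-c3cccc(NC(=O)Nc4ccc(Cl)c(Cl)c4)c3)cc2-c2ccncc2)ccc1Cl` carries a single change relative to compound 1: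

(3,4-dichlorophenyl)amino in place of 4-chloro-3-(trifluoromethyl)phenyl on a carbonyl carbon

Going by the values given here, no step between measured compounds is available, and the expected step is none beyond the scatter, a number no higher from compound 1 to compound 3 (the limit leaves the size open). Compound 3 is estimated at 32500 nM, between 8000 nM and 100000 nM, with a limit the likely report.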

Compound 3, concentration for total growth inhibition: > 50000 nM
Compound 3: a limit, no number; the forecaster's own chance of this, stated with the estimate: 70%; middle value at least 1.5-fold (0.18 log units) from the limit.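

For the compounds shown here, compound 1 and compound 3 each gave only a limit, so no step between them can be read. The compounds shown leave open whether (3,4-dichlorophenyl)amino in place of 4-chloro-3-(trifluoromethyl)phenyl changes growth inhibition at all.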